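From a phenyl amide to a pyridazin-3-yl amide

A few compounds are considered here, and "the series" means these few. Any claim that something is new, unique, unknown or untested is made for them only; others in the source may bear on it.

Compound 1, `CC(C)[C@H](C(=O)NC(C)(C)C)c1ccc(Cl)cc1`, in a functional assay on CHO cells for agonist activity at Free fatty acid receptor 2 (Homo sapiens), read by cAMP accumulation (on this read-out higher numbers stand for weaker inhibition and lower numbers for stronger inhibition), gives > 100000 nM, which is a limit of the assay.
Compound 2, `CC(C)[C@H](C(=O)Nc1ccccc1)c1ccc(Cl)cc1`, gives > 100000 nM, likewise a limit.
Compound 3, `CC(C)C(C(=O)Nc1ncccn1)c1ccc(Cl)cc1`, gives 53000 nM.

Compound 2 therefore stands only at a limit in this assay, and the step that the two limits leave unreadable from compound 1 to compound 2 cannot be sized because both ends sit at the limit of > 100000 nM in this assay, at which 2 of the 3 values shown sit. The compound still to be measured is compound 4, `CC(C)[C@H](C(=O)Nc1cccnn1)c1ccc(Cl)cc1`. It differs from compound 2 by pyridazin-3-yl in place of phenyl on an amide-type nitrogen. For the measured compounds named here, no measured step carries this change: the only recorded step, from a tert-butyl to a phenyl amide, is unreadable, so no measured size can be transferred. What the other pair shows is that compound 3, whose amide-type nitrogen bears a different aromatic ring, returns a number, whereas compound 2 with phenyl returns only a limit. On that slender basis compound 4 is expected to come in near compound 3, at an estimated 60000 nM with a range of 20000 nM to 200000 nM. The expected step is an at least 1.6-fold lower number from compound 2 to compound 4 (0.22 log units; that floor lies within the scatter), though a limit remains a real possibility.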

Compound 4, half-maximal inhibitory concentration: 2300 nM
Beside the measured number, compound 4's estimate is 26-fold (1.42 log units) above it; the whole stated range lies above it.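

In this assay, the group on the amide-type nitrogen now proves able to shift the number by a readable amount: pyridazin-3-yl in place of phenyl gives an at least 43-fold lower number from compound 2 to compound 4 (1.63 log units; beyond the scatter), and pyridazin-3-yl in place of tert-butyl gives an at least 43-fold lower number from compound 1 to compound 4 (1.63 log units; beyond the scatter). Pyridazin-3-yl has the same count of 6 heavy atoms as phenyl, but 2 of its ring atoms are nitrogen and it carries 2 hydrogen-bond acceptors where phenyl has 0. Both steps are floors, and the step between their two starting compounds cannot be read, as each of those compounds stands at a limit: the limit of > 100000 nM in this assay, at which 2 of the 4 values shown sit.

The compounds shown leave open whether both ring nitrogens are needed, which a pyridin-2-yl amide would test. They also leave open whether a methyl group or an amine on the pyridazine ring would lower the number further.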